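The source may hold more compounds than are shown below. What is called first, only, known or untested is meant among the compounds shown, and "the series" means these compounds.

For the measured compounds named here, compound 2 `O=C(CSc1nc(Nc2ccccc2)c2ccccc2n1)Nc1cccc(Br)c1` is one of two compounds measured in a functional assay on PC-3 cells (Homo sapiens) for inhibition, read by MTT assay, with a stated time of 72 h; on this read-out higher numbers stand for weaker inhibition and lower numbers for stronger inhibition. In this assay compound 2 gives 11400 nM. Compound 1 `O=C(CSc1nc(Nc2ccccc2)c2ccccc2n1)Nc1cccc(Cl)c1` carries chloro where compound 2 carries bromo; in this assay compound 1 gives 12600 nM. Going by the values given here, the single step measured so far, a 1.1-fold lower number from compound 1 to compound 2 (0.04 log units; within the scatter), lies within the scatter, so compound 2 and compound 1 stand at the same level, and neither can be called the stronger inhibitor.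

Compound 3 `CCc1cccc(NC(=O)CSc2nc(Nc3ccccc3)c3ccccc3n2)c1` has not yet been measured. It differs from compound 2 in one place: ethyl in place of bromo on an aromatic carbon. Among the compounds with values here, the only measured step that bears on this change is the one from compound 1 to compound 2, and it showed nothing beyond the scatter, so a number near that of compound 2 is expected, with no step beyond the scatter in either direction. The estimate for compound 3 in this assay is 11000 nM, within 5000 nM to 25000 nM. That estimate means an expected step of a 1.0-fold lower number from compound 2 to compound 3 (0.02 log units; within the scatter).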

Compound 3, half-maximal inhibitory concentration: 11000 nM
For compound 3 middle estimate and measured number coincide at the digits printed; the measured number falls inside the stated range.
By their numbers in this assay, from the lowest: compounds 3, 2 and 1 (each within the scatter of the next).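

In this assay, ethyl in place of bromo on the aromatic carbon gives a 1.0-fold lower number from compound 2 to compound 3 (0.02 log units; within the scatter), and ethyl in place of chloro gives a 1.1-fold lower number from compound 1 to compound 3 (0.06 log units; within the scatter). The earlier step compared only two halogens, whereas these steps show that a small carbon chain at this place, meta to a large group, also stands at the same level as both halogens. Nothing available here explains why these three groups stand level.

From the compounds shown here alone, whether that level holds for a different kind of group at this place remains open: an amine, a carboxylic acid or a longer chain such as butyl could match it or depart from it. The compounds shown also do not tell what plain hydrogen there would give, so whether a group at this place matters at all is still unanswered.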